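Replacing the Group on the Carbonyl of Compound 1

The compounds below may be only part of what the source reports. "The series", "measured", "known", "first", "only" and "open" are said of these compounds alone.

- Compound 1 `O=C(NCc1ccc(S(=O)(=O)N2CCCCC2)cc1)c1cc2cnccc2s1` gives 15%
- Compound 2 `O=C(NCc1ccc(S(=O)(=O)c2ccccc2)cc1)c1ccc2cnccc2c1` gives 31%
- Compound 3 `O=C(NCc1ccc(S(=O)(=O)N2CCCCC2)cc1)c1cc2ccncc2[nH]1` is not yet measured

In an ADME assay on microsomes from liver (Homo sapiens) for metabolic stability, read by LC-MS, with a stated time of 30 min, tested at 1 uM (on this read-out higher numbers stand for a more stable compound and lower numbers for a less stable compound), compound 1 stands lowest of the two measured compounds, and compound 2 at 31% lies beyond the scatter from it. Compound 3 differs from compound 1 by one change on a carbonyl carbon a group of 9 heavy atoms (7 carbon, 2 nitrogen; one five-membered aromatic ring with 1 hetero atom, one six-membered aromatic ring with 1 hetero atom) in place of a group of 9 heavy atoms (7 carbon, 1 nitrogen, 1 sulfur; one five-membered aromatic ring with 1 hetero atom, one six-membered aromatic ring with 1 hetero atom), on a carbonyl carbon and the rest stays the same. Among the measured compounds shown here, no measured step covers this change, so only a small rise is expected, with none beyond the scatter. The expected size is a number 5 percentage points higher from compound 1 to compound 3 (within the scatter) in this read-out. Compound 3 is estimated at 20% with an expected range of 7% to 40% for repeated measurements.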

Compound 3, percent of the compound remaining: 50%
Estimate against measurement, compound 3: 30 percentage points below; measured number above the stated range.
By their numbers in this assay, from the lowest: compound 1; then compound 2; then compound 3.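

In this assay, this position on a carbonyl carbon proves highly responsive: the group of 7 carbon and 2 nitrogen atoms, in place of the group of 7 carbon, 1 nitrogen and 1 sulfur, gives a number 35 percentage points higher from compound 1 to compound 3 (beyond the scatter). The entering group has 1 hydrogen-bond donor and the leaving group none, but the step alone cannot separate this difference from the loss of sulfur. Nothing on hand explains the step. On these data alone, it remains open whether a methyl group or a fluorine on the entering group would keep this number. As far as these compounds go, whether the same replacement gives a similar step on the sulfonyl part of compound 2 is also open.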